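Swapping tert-butyl for ethyl on a boron-bearing carbon

The compounds below may be only part of what the source reports. "The series", "measured", "known", "first", "only" and "open" are said of these compounds alone.

Compound 2 (`CC(C)(C)[C@H](NC(=O)N1C/C(=C\c2ccc(F)cc2)C(=O)/C(=C/c2ccc(F)cc2)C1)B1OC(C)(C)C(C)(C)O1`) and compound 1 (`CC(C)C[C@H](NC(=O)[C@H](CC(C)C)NC(=O)N1C/C(=C\c2ccc(F)cc2)C(=O)/C(=C/c2ccc(F)cc2)C1)B1OC(C)(C)C(C)(C)O1`) share a core and both carry a boron-containing end group. In a functional assay on HCT-116 cells (Homo sapiens) for antiproliferative activity, read by MTT assay, with a stated time of 72 h (a lower number here means a stronger inhibitor, a higher number a weaker inhibitor), compound 2 gives 828 nM and compound 1 gives 639 nM. These two numbers lie within the usual scatter of repeated measurements, so compound 2 stands level with compound 1.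

Compound 3 (`CC[C@H](NC(=O)N1C/C(=C\c2ccc(F)cc2)C(=O)/C(=C/c2ccc(F)cc2)C1)B1OC(C)(C)C(C)(C)O1`) has not yet been measured. It keeps the core of compound 2 and makes one change: ethyl in place of tert-butyl on a saturated chain carbon bound to an amide-type nitrogen and a boron atom.

Among the measured compounds shown here, no measured pair differs in only one place, so the data give no direct guide to this swap. There is one weak hint: compound 2 differs from compound 1 in more than one place, yet compound 1 gives 639 nM, within the scatter of compound 2 at 828 nM. No change beyond the scatter is therefore expected in this assay, and the estimate is a 1.2-fold lower number from compound 2 to compound 3 (0.07 log units; within the scatter). For compound 3 the expected value is 700 nM, within an estimated range of 300 nM to 1600 nM.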

Compound 3, half-maximal inhibitory concentration: 876 nM
For compound 3 the middle estimate is 1.3-fold (0.10 log units) below the measured one, within the range that was stated.
By their numbers in this assay, from the lowest: compounds 1, 2 and 3 (each within the scatter of the next).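

Compound 2 and compound 3 form the first pair shown that differs in one place only, so this swap can now be read directly. In this assay ethyl in place of tert-butyl on a saturated chain carbon bound to an amide-type nitrogen and a boron atom gives a 1.1-fold higher number from compound 2 to compound 3 (0.02 log units; within the scatter) and thus no change beyond the scatter, which means that this assay does not tell these two groups apart at this carbon, even though tert-butyl has 4 carbon atoms and ethyl has 2. No supporting measurement is available to explain this outcome.

As far as these compounds go, it remains open whether the reading would also hold with a different kind of group on this carbon, such as a simple hydrogen, a longer chain, a phenyl ring, an amine or a carboxylic acid, as this single step covers only tert-butyl and ethyl. Compound 1 differs from compound 2 and compound 3 in more than one place, so it offers no clean comparison for this carbon, and the result speaks only for the shared core with its boron-containing end group.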